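The source may report more compounds than this note shows. Statements on the series, on what has been measured and on what is new or still open speak of the compounds shown alone.

In an in vitro ADME assay on microsomes from liver (Homo sapiens) for metabolic stability, tested at 1 uM (on this read-out lower numbers stand for a shorter-lived compound and higher numbers for a longer-lived compound), compound 1 `CC(C)[C@]1(C(=O)N2C[C@@H]3C[C@H]2CN3C(=O)OC(C)(C)C)CC[C@@H](NC2CCOCC2)C1` gives > 2 h, which is a limit of the assay rather than a number. Compound 2 `CC(C)[C@]1(C(=O)N2C[C@@H]3C[C@H]2CN3C(=O)CC(C)(C)C)CC[C@@H](NC2CCOCC2)C1` gives > 2 h, again a limit. Compound 3 `CC(C)C(=O)N1C[C@@H]2C[C@H]1CN2C(=O)[C@@]1(C(C)C)CC[C@@H](NC2CCOCC2)C1` gives > 2 h, also a limit. The steps a step that the two limits leave unreadable from compound 1 to compound 2, a step that the two limits leave unreadable from compound 1 to compound 3 and a step that the two limits leave unreadable from compound 2 to compound 3 thus carry no readable size, because of the limit of > 2 h in this assay, at which 3 of the 3 values shown sit. Compound 4 `CC(C)[C@]1(C(=O)N2C[C@@H]3C[C@H]2CN3C(=O)CCC(F)(F)F)CC[C@@H](NC2CCOCC2)C1` differs from compound 1 by 3,3,3-trifluoropropyl in place of tert-butoxy on a carbonyl carbon. Among the measured compounds shown here, since none of the measured changes on that carbonyl carbon moved the read-out off the limit, no step beyond the scatter is foreseen in this assay. Compound 4 is expected to give 3 h in this assay, within 1.5 h to 8 h, and will most likely again be reported only as a limit. The expected step is a step that the limit leaves unreadable from compound 1 to compound 4.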

Compound 4, half-life: > 2 h
Compound 4: no number, only a limit; the forecaster's own chance of this, stated with the estimate: 75%; the middle value does not contradict the limit.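

The steps linking compound 1, compound 2 and compound 3 to compound 4 cannot be read, because all four compounds are reported only as a limit: the limit of > 2 h in this assay, at which 4 of the 4 values shown sit. As far as these compounds go, whether the groups on the carbonyl carbon differ in half-life remains open.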